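A few compounds are considered here, and "the series" means these few. Any claim that something is new, unique, unknown or untested is made for them only; others in the source may bear on it.

Of the compounds shown here, three with a shared core have been tested in an in vitro ADME assay on microsomes from liver (Homo sapiens) for metabolic stability, read by LC-MS, tested at 1 uM; on this read-out higher numbers stand for a longer-lived compound and lower numbers for a shorter-lived compound. Compound 1 `CC(C)N/C(=N\c1nccn1CC(C)(C)C)Nc1ccc(Cl)c(Cl)c1` gives 0.338 h. Compound 2 `CC(C)N/C(=N\c1nccn1C(C)(C)C)Nc1ccc(Cl)c(Cl)c1`, which carries tert-butyl in place of neopentyl on an aromatic nitrogen, gives 0.8 h; that is a 2.4-fold higher number from compound 1 to compound 2 (0.37 log units; beyond the scatter). Compound 3 `CC(C)C(=O)N/C(=N/c1nccn1C(C)C)Nc1ccc(Cl)c(Cl)c1` is different: its result is not a number but a limit of the assay, > 1 h, which is the limit of > 1 h in this assay, at which 1 of the 3 values shown sits. Compound 3 therefore stands at the upper edge of what this assay reports among the three.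

The step from compound 3 to compound 4 `CC(C)n1ccnc1/N=C(/NC(=O)OC(C)(C)C)Nc1ccc(Cl)c(Cl)c1` is tert-butoxy in place of isopropyl on a carbonyl carbon. Among the measured compounds shown here, no measured step touches the same place: the only step recorded is from compound 1 to compound 2, on an aromatic nitrogen, and it is modest in size. There is thus no direct guide to how a change on the carbonyl carbon will shift this assay, and the starting point, a limit, leaves no room to see a rise. Compound 4 is expected to give 1.2 h, with a range from 0.5 h to 3 h. That corresponds to an expected step that the limit leaves unreadable from compound 3 to compound 4, which is best read as no step beyond the scatter.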

Compound 4, half-life: > 1 h
Compound 4: only a limit was reported; the forecaster's own chance of this, stated with the estimate: 55%; the middle value is on the limit's open side.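

In this assay compound 4 gives > 1 h, which is a limit and not a number. Among the compounds shown here, compound 3 also sits at a limit, so no step between compound 3 and compound 4 can be read: the limit of > 1 h in this assay, at which 2 of the 4 values shown sit. The compounds shown leave open whether tert-butoxy in place of isopropyl on a carbonyl carbon changes the half-life at all.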